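Compound 1 to compound 3: one added methyl

The source may hold more compounds than are shown below. What is called first, only, known or untested is meant among the compounds shown, and "the series" means these compounds.

- Compound 1 `O=c1c2cccnc2sn1-c1ccc(Br)cc1` gives 15200 nM
- Compound 2 `O=c1c2cccnc2sn1-c1ccccc1` gives 11200 nM

Among the compounds with values here, in a functional assay on SK-N-SH cells (Homo sapiens) for inhibition (on this read-out lower numbers stand for stronger inhibition of growth and higher numbers for weaker inhibition of growth), compound 1 stands level with the only other compound measured so far. That one step is small (a 1.4-fold lower number from compound 1 to compound 2 (0.13 log units; within the scatter)) and concerns the bromo group, not the carbon changed here. Compound 3 `Cc1cnc2sn(-c3ccc(Br)cc3)c(=O)c2c1` keeps the bromo group and alters the core of compound 1 (methyl in place of hydrogen on an aromatic carbon): methyl in place of hydrogen on an aromatic carbon. Within the data shown here, no measured compound carries this methyl, so no change beyond the scatter is expected (a 1.1-fold lower number from compound 1 to compound 3 (0.04 log units; within the scatter)). For compound 3 the estimate is 14000 nM (expected range 5500 nM to 33000 nM).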

Compound 3, concentration for 50% growth inhibition: 21300 nM
For compound 3 the middle estimate is 1.5-fold (0.18 log units) below the measured one; the measured number falls inside the stated range.
By their numbers in this assay, from the lowest: compounds 2, 1 and 3 (each within the scatter of the next).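

In this assay, methyl in place of hydrogen on an aromatic carbon gives a 1.4-fold higher number from compound 1 to compound 3 (0.15 log units; within the scatter), so adding this group at a carbon two atoms from the ring nitrogen leaves the read-out within the usual scatter. With the bromo group kept, this carbon therefore accepts a methyl without a readable gain or loss in growth inhibition. No measurement is available to explain this result. On these data alone, whether an amine, a carboxylic acid or a longer chain at this carbon would shift the number stays open. Also open, as far as these compounds go, is whether the methyl would behave the same on compound 2, which lacks the bromo group.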